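Amino for Nitro in a Weakly Cytotoxic Compound

The source may hold more compounds than are shown below. What is called first, only, known or untested is meant among the compounds shown, and "the series" means these compounds.

In a functional assay on MCF7 cells (Homo sapiens) for cytotoxicity, read by MTT assay, with a stated time of 72 h (a higher number here means a weaker inhibitor, a lower number a stronger inhibitor), compound 1 (`CCOC(=O)C1=C(C)NC(=S)NC1c1cn(C(=O)CNc2ccccc2[N+](=O)[O-])c2ccccc12`) gives 550 ug/mL as the higher of the two numbers available. Compound 2 (`CCOC(=O)C1=C(C)NC(=O)NC1c1cn(C(=O)CNc2ccc(Cl)cc2)c2ccccc12`) gives 200 ug/mL in this assay and so stands as the stronger inhibitor, with the gap beyond the scatter. Compound 3 (`CCOC(=O)C1=C(C)NC(=S)NC1c1cn(C(=O)CNc2ccccc2N)c2ccccc12`) has not yet been measured. It carries amino in place of nitro on an aromatic carbon of compound 1, ortho to a large group (amino in place of nitro on an aromatic carbon). Within the data shown here, no measured pair shows what this exchange does on its own, so any forecast is uncertain. Compound 2 at 200 ug/mL shows only that a lower number occurs among these compounds. The expected step in this assay is modest, toward a lower number and probably within the scatter (a 1.8-fold lower number from compound 1 to compound 3 (0.26 log units; within the scatter)). For compound 3 the estimated value is 300 ug/mL with an expected range from 110 ug/mL to 800 ug/mL in this measurement.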

Compound 3, half-maximal inhibitory concentration: 100 ug/mL
For compound 3 the middle estimate is 3.0-fold (0.48 log units) above the measured one; the whole stated range lies above it.
By their numbers in this assay, from the lowest: compounds 3 and 2 (each within the scatter of the next); then compound 1.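

In this assay, the exchange of nitro for amino on an aromatic carbon ortho to a large group gives a 5.5-fold lower number from compound 1 to compound 3 (0.74 log units; beyond the scatter) and so provides the first view of a change made in one place only. It shows that this position is not indifferent to the group it carries. With the rest of compound 1 unchanged, the move from 2-nitrophenyl to 2-aminophenyl alone is enough to carry the number beyond the scatter. Nothing at hand explains this step.

The compounds shown leave open whether a hydroxyl, a methoxy or an acetamide at this position would go the same way as amino, or whether amino would give a similar step elsewhere on the ring. They also leave open whether the step would hold on a core bearing a carbonyl in place of the thiocarbonyl.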